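The compounds below may be only part of what the source reports. "The series", "measured", "known", "first", "only" and "open" are said of these compounds alone.

Of the compounds shown here, three that share one core have been tested in a functional assay on cells for agonist activity at C-X-C chemokine receptor type 4 (Homo sapiens), read by fluorescence and calcium flux, with a stated time of 90 s (on this read-out higher numbers stand for an effect only at larger amounts of compound and lower numbers for an effect already at smaller amounts), and all three stop at the same assay limit. Compound 1 `c1ccc2c(c1)CN[C@@H](CN(CCCCNCC1CCNCC1)[C@H]1CCCc3cccnc31)C2` carries a (piperidin-4-yl)methyl group on an amine nitrogen; in this assay compound 1 gives > 30000 nM, which is a limit of the assay rather than a number. Compound 2 `c1ccc2c(c1)CN[C@@H](CN(CCCCNCC1CCSCC1)[C@H]1CCCc3cccnc31)C2` has thian-4-yl in place of piperidin-4-yl on the chain carbon bound to that nitrogen, and compound 2 likewise gives > 30000 nM, again only a limit. Compound 3 `c1ccc2c(c1)CN[C@@H](CN(CCCCNC1CCNCC1)[C@H]1CCCc3cccnc31)C2` shortens the link so that piperidin-4-yl sits directly on the amine nitrogen; compound 3 gives > 30000 nM, once more a limit. Because (the limit of > 30000 nM in this assay, at which 3 of the 3 values shown sit), none of the three steps can be sized: a step that the two limits leave unreadable from compound 1 to compound 2, a step that the two limits leave unreadable from compound 1 to compound 3 and a step that the two limits leave unreadable from compound 2 to compound 3 all remain unreadable.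

Compound 4 `O=S1(=O)CCC(NCCCCN(C[C@H]2Cc3ccccc3CN2)[C@H]2CCCc3cccnc32)CC1` is compound 3 with one change, (1,1-dioxothian-4-yl in place of piperidin-4-yl on an amine nitrogen). For the measured compounds named here, the two steps that touch a ring on this part of the molecule, from compound 1 to compound 2 and from compound 2 to compound 3, both end at the limit, so no measured step reveals a direction for this change. The step from compound 3 to compound 4 is therefore expected to be a step that the limit leaves unreadable from compound 3 to compound 4, meaning no readable shift. Compound 4 is estimated at 40000 nM, within 15000 nM to 100000 nM, most likely reported again only as a limit.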

Compound 4, half-maximal effective concentration: > 30000 nM
Compound 4 gave a limit, no number; the forecaster's own chance of this, stated with the estimate: 85%; the middle value lies beyond the limit too.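

Compound 4, like compound 1, compound 2 and compound 3, gives only a limit and no number, so none of the steps linking these four compounds can be read: the limit of > 30000 nM in this assay, at which 4 of the 4 values shown sit. The compounds shown leave open whether any of the four has an effect in this assay at higher amounts, and how their different groups on the amine nitrogen would compare.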